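The compounds below may be only part of what the source reports. "The series", "measured", "known", "first", "only" and "open" are said of these compounds alone.

Working notes on the series. Compound 1 `Cc1ccc(-c2ccnc(C(=O)Nc3ccc(Oc4ccnc5[nH]ccc45)cc3)n2)cc1` is the reference point. In a functional assay on A549 cells (Homo sapiens) for cytotoxicity, read by MTT assay, with a stated time of 72 h (on this read-out higher numbers stand for weaker inhibition and lower numbers for stronger inhibition), compound 1 gives 2380 nM, the lowest of the two numbers recorded so far. Compound 2 `O=C(Nc1ccc(Oc2ccnc3[nH]ccc23)cc1)c1nccc(-c2ccc(Cl)cc2)n1` gives 22400 nM in this assay. Among the compounds with values here, the step between them, a 9.4-fold higher number from compound 1 to compound 2 (0.97 log units; beyond the scatter), is the only measured step in the set. Compound 3 `O=C(Nc1ccc(Oc2ccnc3[nH]ccc23)cc1)c1nccc(-c2ccc(F)cc2)n1` is recorded in this assay as "not active" (no number reported), with no number attached.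

Compound 4 `Cc1ccc(-c2ccnc(C(=O)Nc3ccc(Oc4ccnc5[nH]ccc45)c(F)c3)n2)cc1` differs from compound 1 by fluoro in place of hydrogen on an aromatic carbon. Within the data shown here, no measured step bears on this change: the one step available, a 9.4-fold higher number from compound 1 to compound 2 (0.97 log units; beyond the scatter), exchanges groups on a different ring, and compound 3 carries no number, so nothing in the set shows how a fluoro entering this ring moves this assay. The working expectation is therefore no step beyond the scatter, with the uncertainty widened for lack of a comparable pair. Compound 4 is estimated at 2500 nM in this assay, with a range of 700 nM to 9000 nM. That estimate means an expected step of a 1.1-fold higher number from compound 1 to compound 4 (0.02 log units; within the scatter).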

Compound 4, half-maximal inhibitory concentration: 1150 nM
Beside the measured number, compound 4's estimate is 2.2-fold (0.34 log units) above it; the range from low to high includes it.
By their numbers in this assay, from the lowest: compound 4; then compound 1; then compound 2.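

In this assay, within the data shown here, fluoro in place of hydrogen on an aromatic carbon, ortho to a large group and meta to a large group, gives a 2.1-fold lower number from compound 1 to compound 4 (0.32 log units; beyond the scatter) and is the only measured change on this ring. The earlier measured step, a 9.4-fold higher number from compound 1 to compound 2 (0.97 log units; beyond the scatter), exchanged groups on a different ring and raised the number, whereas this change lowers it, so this position admits a single fluoro without loss in this assay. Nothing measured here accounts for the step.

On these data alone, whether an amine, a methoxy group or a longer chain on the same carbon would extend or reverse this modest step remains open. Also open, as far as these compounds go, is whether fluoro at this position gives a similar step when the methyl of compound 1 is replaced by chloro, as in compound 2.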